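This account rests on a few compounds, and the source may have more. Where it says the series, first, only, none or still open, it means among the compounds named here.

Measured compounds:
compound 1, `CC(C)(C)C1=C(C(=O)O)N2C(=O)[C@H](CO)[C@H]2O1`, 5 h
compound 2, `CC(C)(C)C1=C(C(=O)O)N2C(=O)[C@H]([C@@H](O)c3ccccc3)[C@H]2O1`, 8.9 h

In an ADME assay, in phosphate buffer, at 28 degrees C, at pH 7.0 (on this read-out lower numbers stand for a shorter-lived compound and higher numbers for a longer-lived compound), compound 1 gives 5 h, the lowest of the two numbers; its nearest neighbour is compound 2, which gives 8.9 h, a difference that lies within the scatter. The change from compound 1 to compound 3, `C[C@H](F)[C@H]1C(=O)N2C(C(=O)O)=C(C(C)(C)C)O[C@H]12`, is 1-fluoroethyl in place of hydroxymethyl on a saturated ring carbon. Among the compounds with values here, the one measured step, a 1.8-fold higher number from compound 1 to compound 2 (0.25 log units; within the scatter), concerns a different place on the shared core, a phenyl in place of hydrogen on a saturated chain carbon bound to an oxygen on a saturated carbon and a saturated ring carbon, and is itself within the scatter; no measured step exchanges the hydroxymethyl on the four-membered ring for a group without a hydrogen-bond donor or acceptor, so there is nothing in hand that speaks for a large shift in either direction. The half-life of compound 3 in this assay is therefore expected to stay close to that of compound 1, with the estimated step of a 1.2-fold higher number from compound 1 to compound 3 (0.08 log units; within the scatter). Compound 3 is estimated at 6 h, within a range of 2.5 h to 14 h.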

Compound 3, half-life: 7.2 h
Compound 3: the middle estimate sits 1.2-fold (0.08 log units) below what was measured; the measured number falls inside the stated range.
By their numbers in this assay, from the lowest: compounds 1, 3 and 2 (each within the scatter of the next).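

In this assay, 1-fluoroethyl in place of hydroxymethyl on a saturated ring carbon of the four-membered ring gives a 1.4-fold higher number from compound 1 to compound 3 (0.16 log units; within the scatter), so this exchange cannot be told apart from no change on this read-out. Within the data shown here, compounds 1 and 2 both keep a hydroxyl on the chain at this place, whereas compound 3 is the first of the series to carry a group with 0 hydrogen-bond donors and 0 hydrogen-bond acceptors, and its half-life still stays within the scatter of that of compound 1. No measurement at hand explains this reading or bears on this result.

The compounds shown leave open whether a plain ethyl, which would separate the fluorine from the added carbon, or the opposite configuration at the fluorine-bearing carbon would read the same way in this assay. Among these compounds, they also leave open whether an amine, a carboxylic acid or a longer chain on this saturated ring carbon would move the half-life beyond the scatter, since the three compounds so far span only a narrow set of neutral groups at this place.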